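Swapping the aryl group on the shared core of compound 1

The source may hold more compounds than are shown below. What is called first, only, known or untested is meant among the compounds shown, and "the series" means these compounds.

Measured compounds:
- compound 1, `COc1cc(C2=NN(C(C)=O)C(c3cccc(F)c3)O2)cc(OC)c1OC`: 16.5%
- compound 2, `COc1ccc(/C=N/NC(=O)c2cc(OC)c(OC)c(OC)c2)c(OC)c1`: 10%
- compound 3, `COc1cc(C(=O)N/N=C/c2ccc(F)c(F)c2)cc(OC)c1OC`: 35.1%

Of the compounds shown here, three have been tested in a functional assay on PC-3 cells (Homo sapiens) for antiproliferative activity, read by MTT assay, tested at 1 uM; on this read-out higher numbers stand for a stronger effect at the one concentration tested and lower numbers for a weaker effect. Compound 1 gives 16.5% in this assay. Compound 2 gives 10%, a figure that lies within the usual scatter of that of compound 1, so the two cannot be told apart on these numbers. Compound 3 gives 35.1%, which lies beyond the scatter above compound 1; this is the only separation among the three that counts as real. Going by the values given here, no pairs that differ in a single place have been measured, so no step of known size is available to guide an expectation.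

The unmeasured compound 4, `COc1cc(C2=NN(C(C)=O)C(c3ccccc3C(F)(F)F)O2)cc(OC)c1OC`, is derived from compound 1 by one change: 2-(trifluoromethyl)phenyl in place of 3-fluorophenyl on a saturated ring carbon. Among the compounds with values here, both groups are aryl rings carrying fluorine, and nothing among the measured compounds shows how this particular exchange moves the read-out. Within the data shown here, with no comparable step to lean on, the expected step from compound 1 to compound 4, a number 1.5 percentage points higher from compound 1 to compound 4 (within the scatter), is taken as none beyond the scatter. Compound 4 is therefore estimated at 18%, with a range from 5% to 35%.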

Compound 4, a percentage reported as inhibition, at one concentration (the size of the read-out at that concentration, not a potency): -11%
Compound 4: middle estimate off by 29 percentage points, on the high side; the measured number lies below the stated range.
By their numbers in this assay, from the lowest: compound 4; then compounds 2 and 1 (each within the scatter of the next); then compound 3.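

On the shared core of compound 1, the aryl group on the saturated ring carbon turns out to matter: in this assay, 2-(trifluoromethyl)phenyl in place of 3-fluorophenyl gives a number 27.5 percentage points lower from compound 1 to compound 4 (beyond the scatter), the first single-place step available in this series. The change thus carries the read-out down by more than the usual scatter, and compound 4, at -11%, ends on the negative side of zero, so this exchange yields no measured inhibition at the one concentration tested. Nothing at hand explains why this exchange lowers the read-out.

The exchange alters both the fluorinated group and its printed place on the aryl ring, so the compounds shown cannot assign the step to either alteration alone. Also open, from the compounds shown here alone, is how the read-out would respond to an aryl ring bearing an amine or a carboxylic acid at this position, or to a longer alkyl chain in place of the aryl group.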